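Hydrazone nitrogen substituent in a benzyloxy coumarinyl series

This account rests on a few compounds, and the source may have more. Where it says the series, first, only, none or still open, it means among the compounds named here.

Measured so far:
compound 1 `N/N=C\c1cc(=O)oc2cc(OCc3ccccc3)cc(OCc3ccccc3)c12` — 363000 nM
compound 2 `O=c1cc(/C=N\Nc2ccc([N+](=O)[O-])cc2)c2ccc(OCc3ccccc3)cc2o1` — 9510 nM
compound 3 `O=c1cc(/C=N\Nc2ccccc2)c2ccc(OCc3ccccc3)cc2o1` — 13200 nM

In a functional assay, read by spectrophotometry, with a stated time of 3 min (a higher number here means a weaker inhibitor, a lower number a stronger inhibitor), compound 3 stands second highest of the three numbers, within the scatter of compound 2 and well apart from compound 1. For the measured compounds named here, the single measured step, a 1.4-fold higher number from compound 2 to compound 3 (0.14 log units; within the scatter), is hydrogen in place of nitro on an aromatic carbon and lies within the scatter.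

Compound 4 `N/N=C\c1cc(=O)oc2cc(OCc3ccccc3)ccc12` differs from compound 3 by hydrogen in place of phenyl on an amine nitrogen, anilino to amino. The measured step does not bear on this change: it alters a substituent on the aromatic ring, not the presence of that ring. Going by the values given here, compound 1, which also carries hydrogen on the amine nitrogen but a different pattern of benzyloxy groups, gives 363000 nM; no single step links it to compound 3, and its number only shows that the one amino compound measured is weaker in this assay. On that basis a higher number is expected for compound 4, a 9.1-fold higher number from compound 3 to compound 4 (0.96 log units; beyond the scatter), with wide uncertainty. Compound 4 is estimated at 120000 nM, range 20000 nM to 600000 nM.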

Compound 4, half-maximal inhibitory concentration: 9740 nM
Compound 4: the middle estimate sits 12-fold (1.09 log units) above what was measured; the measured number lies below the stated range.
By their numbers in this assay, from the lowest: compounds 2, 4 and 3 (each within the scatter of the next); then compound 1.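

In this assay the amine nitrogen tolerates loss of its aryl group: hydrogen in place of phenyl (a 1.4-fold lower number from compound 3 to compound 4 (0.13 log units; within the scatter)) and hydrogen in place of 4-nitrophenyl (a 1.0-fold higher number from compound 2 to compound 4 (0.01 log units; within the scatter)) both stay within the scatter, so compounds 2, 3 and 4 do not separate at this position. The large gap sits at a different place, hydrogen in place of benzyloxy on an aromatic carbon (a 37-fold lower number from compound 1 to compound 4 (1.57 log units; beyond the scatter)), so the high number of compound 1 goes with its extra benzyloxy and not with the unsubstituted amino end. Nothing at hand accounts for either result.

Open, as far as these compounds go, is whether an acetyl group or a methyl or longer alkyl chain on the amine nitrogen also stays within the scatter of compound 4. Also open, from the compounds shown here alone, is whether a hydroxyl or methoxy group in place of the extra benzyloxy of compound 1 gives a number close to that of compound 4.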